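Benzylamino Sulfonamide in Place of the Chlorophenyl Sulfone

This account rests on a few compounds, and the source may have more. Where it says the series, first, only, none or still open, it means among the compounds named here.

Compound 3 `O=C(NCc1ccncc1)Nc1ccc(S(=O)(=O)c2ccc(Cl)cc2)cc1` gives 126 nM in an assay on isolated protein for activation of Nicotinamide phosphoribosyltransferase (Homo sapiens) (on this read-out lower numbers stand for an effect already at smaller amounts and higher numbers for an effect only at larger amounts of compound), and stands second highest of the three numbers: compound 1 `O=C(NCc1ccncc1)Nc1ccc(S(=O)(=O)c2ccccc2Cl)cc1` gives 79 nM, a step within the scatter (a 1.6-fold higher number from compound 1 to compound 3 (0.20 log units; within the scatter)), while compound 2 `O=C(NCc1ccncc1)Nc1ccc(S(=O)(=O)N2CC3CCC(C2)O3)cc1` gives 279 nM, with the step of a 2.2-fold lower number from compound 2 to compound 3 (0.35 log units; beyond the scatter) lying beyond it. Compound 4 `O=C(NCc1ccncc1)Nc1ccc(S(=O)(=O)NCc2ccccc2)cc1` carries benzylamino in place of 4-chlorophenyl on a sulfonyl sulfur. The two measured steps that bear on this swap, a nitrogen-bound group replacing a chlorophenyl on the sulfonyl sulfur, are a 3.5-fold higher number from compound 1 to compound 2 (0.55 log units; beyond the scatter) and, read the other way, a 2.2-fold lower number from compound 2 to compound 3 (0.35 log units; beyond the scatter): both modest, both moving toward higher numbers when the chlorophenyl leaves. For compound 4 the same direction is therefore expected, a step of a 2.0-fold higher number from compound 3 to compound 4 (0.30 log units; within the scatter). Compound 4 is estimated at 250 nM, within a range from 100 nM to 650 nM.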

Compound 4, half-maximal effective concentration: 102 nM
Beside the measured number, compound 4's estimate is 2.5-fold (0.39 log units) above it; low and high end bracket the measured number.
By their numbers in this assay, from the lowest: compounds 1, 4 and 3 (each within the scatter of the next); then compound 2.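

Benzylamino on the sulfonyl sulfur holds up as well as either chlorophenyl group (a 1.2-fold lower number from compound 3 to compound 4 (0.09 log units; within the scatter); a 1.3-fold higher number from compound 1 to compound 4 (0.11 log units; within the scatter)). The nitrogen-bound groups do not behave alike (a 2.7-fold lower number from compound 2 to compound 4 (0.44 log units; beyond the scatter)), so a nitrogen link on the sulfonyl sulfur does not by itself bring the higher number of compound 2. Nothing at hand gives a reason for this.

The compounds shown leave open whether a shorter methylamino group or a longer phenethylamino chain on the sulfonyl sulfur would stay in this range. They also leave open whether the benzylamino hydrogen on nitrogen matters, which a methyl group there would test.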